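Working notes: fluoro in place of hydrogen, compound 3

A few compounds are considered here, and "the series" means these few. Any claim that something is new, unique, unknown or untested is made for them only; others in the source may bear on it.

Measured so far in a functional assay on OVCAR-3 cells (Homo sapiens) for cytotoxicity, read by MTT assay, with a stated time of 6 days; on this read-out higher numbers stand for weaker inhibition and lower numbers for stronger inhibition:
- compound 1 `CC(=O)N[C@@H](CSC(=O)Nc1ccc(Br)cc1)C(=O)O` gives > 200000 nM as a limit of the assay
- compound 2 `CC(=O)N[C@@H](CSC(=O)Nc1ccccc1)C(=O)O` gives 153000 nM as a number

Compound 2 holds the only number shown. Among the compounds with values here, the one other reading is the limit of > 200000 nM in this assay, at which 1 of the 2 values shown sits, a limit held by compound 1.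

Compound 3 `CC(=O)N[C@@H](CSC(=O)Nc1ccc(F)cc1)C(=O)O` is not yet measured and carries fluoro in place of hydrogen on an aromatic carbon as its change, para to a large group. Within the data shown here, one measured step bears on this change: an at least 1.3-fold lower number from compound 1 to compound 2 (0.11 log units; that floor lies within the scatter) for hydrogen in place of bromo on an aromatic carbon. That step rests on a limit, and its floor lies within the scatter, so it offers no firm size or direction.

The expected move is a 1.1-fold higher number from compound 2 to compound 3 (0.03 log units; within the scatter) in this assay, with no change beyond the scatter anticipated. For compound 3 an estimated 165000 nM is expected, with an expected range from 95000 nM to 280000 nM in this read-out.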

Compound 3, half-maximal inhibitory concentration: > 200000 nM
Compound 3 gave a limit, no number; the forecaster's own chance of this, stated with the estimate: 30%; at least 1.2-fold (0.08 log units) between middle value and limit.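

In this assay, fluoro on the aromatic carbon para to a large group also fails to give a number: compound 3 gives > 200000 nM, which is a limit of the assay. Fluoro in place of hydrogen gives an at least 1.3-fold higher number from compound 2 to compound 3 (0.11 log units; that floor lies within the scatter), so no firm size or direction follows for this change, and the step between the bromo and fluoro compounds cannot be read, as both ends are limits. Both halogen compounds read as limits and compound 2 alone holds a number, which leaves little room for comparison: the limit of > 200000 nM in this assay, at which 2 of the 3 values shown sit.

Open, going by these compounds, is whether an amine or a nitrile at this position would move the number beyond the scatter from compound 2. Also open, on these data alone, is whether an ester in place of the carboxylic acid, or a longer chain in place of the acetyl group, would give readable numbers on the shared core.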